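Carboxy for nitro on a nitrobenzenesulfonamide scaffold

The source may hold more compounds than are shown below. What is called first, only, known or untested is meant among the compounds shown, and "the series" means these compounds.

The measured compounds:
compound 1, `CCCCCCNc1ccc([N+](=O)[O-])cc1S(N)(=O)=O`: 3.8%
compound 2, `CCCCCCNc1ccc([N+](=O)[O-])cc1S(=O)(=O)N(C)C`: 4.9%
compound 3, `CN(C)S(=O)(=O)c1cc([N+](=O)[O-])ccc1NCCC(C)(C)C`: 17%

In an assay on HEK293 cells for inhibition of solute carrier family 12 member 2 (Homo sapiens), read by fluorescence, with a stated time of 30 min, tested at 100 uM (on this read-out lower numbers stand for a weaker effect and higher numbers for a stronger effect at the one concentration tested), compound 2 sits second highest of the three numbers. Its nearest neighbour is compound 1, with a number 1.1 percentage points higher from compound 1 to compound 2 (within the scatter) between them; its furthest is compound 3, reached by a number 12.1 percentage points higher from compound 2 to compound 3 (beyond the scatter). Compound 4, `CCCCCCNc1ccc(C(=O)O)cc1S(=O)(=O)N(C)C`, has not been measured in this assay. Compared with compound 2 it shows the following change: carboxy in place of nitro on an aromatic carbon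

Neither measured step bears on this change. The step from compound 1 to compound 2 alters a group on a sulfonyl sulfur and stays within the scatter; the step from compound 2 to compound 3 alters a saturated chain and is modest. Nothing measured here touches the nitro group, so there is no ground to expect a step beyond the scatter in this assay in either direction. The expected step is a number 0.1 percentage points higher from compound 2 to compound 4 (within the scatter). For compound 4 the estimate is 5%, with a range from -5% to 18%.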

Compound 4, a percentage reported as inhibition, at one concentration (the size of the read-out at that concentration, not a potency): 19.8%
Estimate against measurement, compound 4: 14.8 percentage points below, and the stated range ends below it.
By their numbers in this assay, from the lowest: compounds 1 and 2 (each within the scatter of the next); then compounds 3 and 4 (each within the scatter of the next).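

Among the compounds shown, only this change touches the aromatic carbon para to the hexylamino group, and it shows that this position is not silent in this assay: carboxy in place of nitro gives a number 14.9 percentage points higher from compound 2 to compound 4 (beyond the scatter). The two groups match in heavy atoms, and the computed difference between them includes a hydrogen-bond donor on carboxy that nitro lacks, so a step of this size can arise without any change in the number of heavy atoms there. No evidence given here accounts for the step.

As far as these compounds go, whether a methyl ester or a primary amide at this position would read like carboxy or like nitro stays open. So does whether carboxy would give a similar step on the chain of compound 3 or with the unsubstituted sulfonamide of compound 1.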